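This account rests on a few compounds, and the source may have more. Where it says the series, first, only, none or still open, it means among the compounds named here.

Compound 1, `COc1cccc(COc2ccc3cc(C(=O)/C=C/c4cc(OC)ccc4OC)c(=O)oc3c2)c1`, gives > 100000 nM in a functional assay on MCF7 cells (Homo sapiens) for cytotoxicity, read by MTT assay, with a stated time of 72 h; on this read-out lower numbers stand for stronger inhibition and higher numbers for weaker inhibition.
Compound 2, `COc1cccc(COc2ccc3cc(C(=O)/C=C/c4ccc(Cl)cc4Cl)c(=O)oc3c2)c1`, gives "not determined" (no result reported) in this assay.

The result for compound 1 is a limit of the assay and not a number. Compound 2 carries no value at all in this assay, so it stands nowhere on the numbers shown; the only figure in hand is the limit of > 100000 nM in this assay, at which 1 of the 2 values shown sits, and that belongs to compound 1. Going by the values given here, no step between two measured compounds can therefore be read off.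

Compound 3, `COc1cccc(COc2ccc3cc(C(=O)/C=C/c4ccccc4)c(=O)oc3c2)c1`, differs from compound 2 in one place: phenyl in place of 2,4-dichlorophenyl on a double-bonded chain carbon bound to a double-bonded chain carbon. Both keep the same core and the same chain linking it to the aromatic ring.

Among the compounds with values here, since no measured step is available, the size and direction of the change from compound 2 to compound 3 in this assay cannot be taken from the data, and no move beyond the usual scatter can be claimed in either direction. Compound 3 is expected to give about 80000 nM, with the estimate spanning 20000 nM to 300000 nM, and a fair chance that only a limit is reported.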

Compound 3, half-maximal inhibitory concentration: 33700 nM
Estimate against measurement, compound 3: 2.4-fold (0.38 log units) above; measured number inside the range.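

In this assay, this position now gives a real number: with phenyl on a double-bonded chain carbon bound to a double-bonded chain carbon, compound 3 gives 33700 nM and is no longer out of the assay's range. The result for compound 1, which carries 2,5-dimethoxyphenyl in that place, is a limit of the assay and not a number: the limit of > 100000 nM in this assay, at which 1 of the 3 values shown sits. From the compounds shown here alone, exchanging 2,5-dimethoxyphenyl for phenyl brings an at least 2.9-fold lower number from compound 1 to compound 3 (0.47 log units; beyond the scatter) and shows that the group at this one place can shift the read-out toward stronger inhibition, although the true size of the step stays unknown, as one end of it is only a limit.

Going by these compounds, compound 2 has no reported result, so its step to compound 3 cannot be read, and what 2,4-dichlorophenyl does at this place remains open. Also open, on these data alone, is whether an amine or a carboxylic acid on the phenyl ring of compound 3 would lower or raise the number, as a single measured number and a single limit cannot yet show a trend across groups at this place.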